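The compounds below may be only part of what the source reports. "The series", "measured", "known", "first", "only" and "open" are said of these compounds alone.

In a functional assay on PC-3 cells (Homo sapiens) for cytotoxicity, read by MTT assay, with a stated time of 48 h (a lower number here means a stronger inhibitor, a higher number a weaker inhibitor), compound 1 `CC1(C)CCC[C@]2(C)[C@@H](CC[C@@](C)(O)/C=C/c3ccccc3)[C@](C)(O)CC[C@@H]12` gives 121 nM. Compound 2 `COc1cccc(OC)c1/C=C/[C@](C)(O)CC[C@@H]1[C@@]2(C)CCCC(C)(C)[C@@H]2CC[C@@]1(C)O` gives 4000 nM and sits level with compound 3 `COc1cccc(/C=C/[C@](C)(O)CC[C@@H]2[C@@]3(C)CCCC(C)(C)[C@@H]3CC[C@@]2(C)O)c1OC` at 2900 nM, as a 1.4-fold lower number from compound 2 to compound 3 (0.14 log units; within the scatter) shows, with both far from compound 1. Compound 4 `CC1(C)CCC[C@]2(C)[C@@H](CC[C@@](C)(O)/C=C/c3ccc(C(=O)O)cc3)[C@](C)(O)CC[C@@H]12` follows from compound 2 by one change: 4-carboxyphenyl in place of 2,6-dimethoxyphenyl on a double-bonded chain carbon bound to a double-bonded chain carbon. The large steps of a 33-fold higher number from compound 1 to compound 2 (1.52 log units; beyond the scatter) and a 24-fold higher number from compound 1 to compound 3 (1.38 log units; beyond the scatter) bear on this change, since both lead away from the unsubstituted phenyl. Among the measured compounds shown here, no measured compound carries 4-carboxyphenyl, so only part of that distance is expected to be recovered. The expected step is a 2.7-fold lower number from compound 2 to compound 4 (0.43 log units; beyond the scatter), towards a lower number. For compound 4 the estimated value is 1500 nM, with an expected range of 250 nM to 9000 nM.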

Compound 4, half-maximal inhibitory concentration: 102 nM
Compound 4: the middle estimate sits 15-fold (1.17 log units) above what was measured; the measured number lies below the stated range.
By their numbers in this assay, from the lowest: compounds 4 and 1 (each within the scatter of the next); then compounds 3 and 2 (each within the scatter of the next).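

In this assay, the substituted phenyl on this double-bonded chain carbon does not by itself cost activity: 4-carboxyphenyl recovers the distance lost with the dimethoxyphenyl groups, at a 39-fold lower number from compound 2 to compound 4 (1.59 log units; beyond the scatter) and a 28-fold lower number from compound 3 to compound 4 (1.45 log units; beyond the scatter) against them. Carboxy in place of hydrogen on an aromatic carbon stays within the scatter (a 1.2-fold lower number from compound 1 to compound 4 (0.07 log units; within the scatter)), so this place tolerates that group as well as the unsubstituted phenyl. Nothing available here explains the difference between 4-carboxyphenyl and the dimethoxyphenyl groups. As far as these compounds go, whether a methyl ester or a primary amide in place of the carboxy group would hold this level stays open. So does how a single methoxy group on the phenyl would behave.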